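A few compounds are considered here, and "the series" means these few. Any claim that something is new, unique, unknown or untested is made for them only; others in the source may bear on it.

Compound 1 `COc1ccc2c(c1)C=C1Cn3c-2c(C2CCCCC2)c2ccc(cc23)C(=O)NS(=O)(=O)N(C)CCCN(C)C1=O`: > 25000 nM
Compound 2 `COc1ccc2c(c1)C[C@H]1Cn3c-2c(C2CCCCC2)c2ccc(cc23)C(=O)NS(=O)(=O)N(C)CCOCCN(C)C1=O`: > 25000 nM

Both compounds were tested in an ADME assay on MT4 cells (Homo sapiens) for cytotoxicity; a lower number here means that less compound is tolerated, a higher number that more compound is tolerated. There, compound 2 gives > 25000 nM, which is a limit of the assay and not a number. Compound 1 gives > 25000 nM, which is also a limit. Compound 2 therefore has no exact value to be ranked on, and the limit of > 25000 nM in this assay, at which 2 of the 2 values shown sit, describes all that has been measured so far.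

Compound 3 `COc1ccc2c(c1)C[C@@H]1Cn3c-2c(C2CCCCC2)c2ccc(cc23)C(=O)NS(=O)(=O)N(C)CCOCCN(C)C1=O` is the next to be tested. It is related to compound 2 as follows: the two compounds have the same atoms and bonds and differ only in configuration as drawn: 1 of 1 stereo elements differ; a stereocentre at a saturated ring carbon is drawn S in compound 2 and R in compound 3. No change beyond the usual scatter is expected in this assay, and the expectation rests on compound 2 with its limit of > 25000 nM. The expected change is a number no higher from compound 2 to compound 3 (the limit leaves the size open), and it can be read only loosely against a limit. For compound 3 the estimated half-maximal cytotoxic concentration is 25000 nM, within an expected range of 12000 nM to 50000 nM.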

Compound 3, half-maximal cytotoxic concentration: > 25000 nM
Compound 3: a limit, no number (the forecaster's own chance of this, stated with the estimate: 85%); the middle value sits exactly at the limit.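

In this assay compound 3 gives > 25000 nM, which is a limit of the assay and not a number. Among these compounds, compound 2 also sits at a limit, so no step between compound 2 and compound 3 can be read. The compounds shown leave open whether the two configurations differ in cytotoxicity at all.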